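The source may report more compounds than this note shows. Statements on the series, on what has been measured and on what is new or still open speak of the compounds shown alone.

Compound 1 `CC(=O)Nc1cccc(S(=O)(=O)Oc2ccccc2C(C)C)c1` — 21000 nM
Compound 2 `CCC(=O)Nc1ccc(S(=O)(=O)Oc2ccccc2C(C)C)cc1` — 11000 nM
Compound 3 `CCC(=O)Nc1ccc(S(=O)(=O)Oc2ccccc2I)cc1` — 8100 nM

Of the compounds shown here, three sharing one core have been measured in a functional assay on MCF7 cells (Homo sapiens) for antiproliferative activity, read by sulforhodamine B assay, with a stated time of 48 h; on this read-out lower numbers stand for stronger inhibition and higher numbers for weaker inhibition. Compound 2 sits second highest of the three numbers. Its nearest neighbour is compound 3, reached by a 1.4-fold lower number from compound 2 to compound 3 (0.13 log units; within the scatter), a change at the phenyl ester end of the molecule. Compound 1 lies on the other side of compound 2, and the two values differ within the scatter, so no order between them can be claimed.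

Compound 4 `CCCCCC(=O)Nc1ccc(S(=O)(=O)Oc2ccccc2C(C)C)cc1` is the next compound to be measured in this assay. It differs from compound 2 by propyl in place of hydrogen on a saturated chain carbon, two bonds along the chain from a carbonyl carbon: the short amide chain is lengthened while everything else is kept. Going by the values given here, none of the measured steps touches this chain; the only measured step, a 1.4-fold lower number from compound 2 to compound 3 (0.13 log units; within the scatter), changes a substituent on the other aromatic ring and stays within the scatter. Among the compounds with values here, with no direct precedent, the expected step for compound 4 is a 1.2-fold lower number from compound 2 to compound 4 (0.09 log units; within the scatter). Compound 4 is therefore estimated at 9000 nM, within a range of 3000 nM to 27000 nM.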

Compound 4, half-maximal inhibitory concentration: 5300 nM
Compound 4: the middle estimate sits 1.7-fold (0.23 log units) above what was measured, and the stated range covers the measured number.
By their numbers in this assay, from the lowest: compounds 4, 3, 2 and 1 (each within the scatter of the next, the first and the last beyond it).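

In this assay, going by these compounds alone, the amide chain is the first place where a single change moves the number beyond the usual scatter: going from propanoyl to pentylcarbonyl gives a 2.1-fold lower number from compound 2 to compound 4 (0.32 log units; beyond the scatter). The step is modest, but the earlier change on the other aromatic ring, a 1.4-fold lower number from compound 2 to compound 3 (0.13 log units; within the scatter), stayed within the scatter, so this chain is the one position shown so far to respond. Nothing measured here explains why the longer chain goes with the lower number.

From the compounds shown here alone, one lengthening does not make a trend, so it remains open whether a still longer chain, or a chain carrying an amine or a carboxylic acid, would lower the number further or raise it again. Going by these compounds, it is also open whether the same lengthening would give a similar step with the iodo group of compound 3 in place of isopropyl.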